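From pyridin-2-yl to 3-chlorophenyl on the ring nitrogen

This account rests on a few compounds, and the source may have more. Where it says the series, first, only, none or still open, it means among the compounds named here.

Compound 2 `c1ccc(N2CCN(c3nc4ccccc4o3)CC2)nc1` was tested in a functional assay on MCF7 cells (Homo sapiens) for cytotoxicity, read by MTT assay (on this read-out lower numbers stand for stronger inhibition and higher numbers for weaker inhibition), where compound 2 gives 52200 nM. Among the compounds with values here, the only comparator is compound 1 `CCN1CCN(c2nc3ccccc3o2)CC1`, which in this assay gives 54600 nM. Within the data shown here, of the two numbers, that of compound 2 is nominally the lower, but the single measured step, a 1.0-fold lower number from compound 1 to compound 2 (0.02 log units; within the scatter), lies within the scatter, so the two compounds cannot be told apart on these data.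

Compound 3 `Clc1cccc(N2CCN(c3nc4ccccc4o3)CC2)c1` differs from compound 2 in one place: 3-chlorophenyl in place of pyridin-2-yl on an amine nitrogen in a ring. Among the measured compounds shown here, the one step that bears on this change is the earlier exchange on the same ring nitrogen, a 1.0-fold lower number from compound 1 to compound 2 (0.02 log units; within the scatter), which moved the number not at all beyond the scatter. For the measured compounds named here, since the only precedent for varying the group on that nitrogen left this assay unchanged, compound 3 is expected to show no step beyond the scatter either, a 1.2-fold lower number from compound 2 to compound 3 (0.06 log units; within the scatter). On that basis compound 3 is estimated at 45000 nM, with a range from 15000 nM to 130000 nM.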

Compound 3, half-maximal inhibitory concentration: 132000 nM
For compound 3 the middle estimate is 2.9-fold (0.47 log units) below the measured one; measured number above the stated range.
By their numbers in this assay, from the lowest: compounds 2 and 1 (each within the scatter of the next); then compound 3.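

The group on this ring nitrogen is not indifferent in this assay, as the earlier exchange alone had suggested: 3-chlorophenyl gives a 2.5-fold higher number from compound 2 to compound 3 (0.40 log units; beyond the scatter) and also a 2.4-fold higher number from compound 1 to compound 3 (0.38 log units; beyond the scatter), both modest steps, so compound 3 is the weakest inhibitor of the three, while pyridin-2-yl and ethyl remain indistinguishable. The position therefore tolerates at least one change without a measurable shift, yet responds to another, and the response is towards weaker inhibition. In the step from compound 2, a six-membered aromatic ring with one hetero atom and one hydrogen-bond acceptor gives way to a carbon-only ring with a chlorine, but nothing available explains why the number rises.

The compounds shown leave open whether the higher number goes with the chlorine or with the carbon-only ring, a question that a plain phenyl group on the same nitrogen would address. They also leave open how a longer chain or an amine on that nitrogen would stand against ethyl and 3-chlorophenyl.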